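Replacing the side arm of compound 2

The source may report more compounds than this note shows. Statements on the series, on what has been measured and on what is new or still open speak of the compounds shown alone.

In a functional assay on NCI-H460 cells (Homo sapiens) for positive allosteric modulation, read by MTT assay, with stated times of 2 h and 72 h, tested at 1 uM (on this read-out lower numbers stand for stronger inhibition and higher numbers for weaker inhibition), compound 1 `COc1cccc(-n2nnc(-c3ccccc3NC(=O)c3ccc(N=[N+]=[N-])cc3)n2)c1` gives 558 nM and compound 2 `COc1cccc(-n2nnc(-c3ccccc3NC(=O)c3ccc(NC(=O)CBr)cc3)n2)c1` gives 241 nM as the lower of the two numbers. Among the compounds with values here, the one measured step is a 2.3-fold lower number from compound 1 to compound 2 (0.36 log units; beyond the scatter) and is modest though beyond the usual scatter; it puts ((bromomethyl)carbonyl)amino in place of azido on an aromatic carbon. Compound 3 `COc1cccc(-n2nnc(-c3ccccc3NC(=O)Nc3ccc(N)cc3)n2)c1` carries (4-aminophenyl)amino in place of 4-(((bromomethyl)carbonyl)amino)phenyl on a carbonyl carbon and loses the group gained in that step. Within the data shown here, no measured compound shows this swap, and the guide is a loose one. Among the measured compounds shown here, compound 2 with 241 nM holds the lower number so far, and a higher number in this assay is expected, somewhat larger than the measured step. The expected change is a 2.9-fold higher number from compound 2 to compound 3 (0.46 log units; beyond the scatter) at this estimate. For compound 3 the estimated value is 700 nM within an expected range of 180 nM to 2800 nM on repeat measurement.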

Compound 3, half-maximal inhibitory concentration: 228 nM
Beside the measured number, compound 3's estimate is 3.1-fold (0.49 log units) above it; the range from low to high includes it.
By their numbers in this assay, from the lowest: compounds 3 and 2 (each within the scatter of the next); then compound 1.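

In this assay, (4-aminophenyl)amino in place of 4-(((bromomethyl)carbonyl)amino)phenyl on the carbonyl carbon gives a 1.1-fold lower number from compound 2 to compound 3 (0.02 log units; within the scatter), so this position accepts two quite different arms with no readable change in the number. The bromomethyl carbonyl group is thus not required for a number of this size, at least among these compounds, and compound 3 has none of it. Against the azido arm, the new group gives a 2.4-fold lower number from compound 1 to compound 3 (0.39 log units; beyond the scatter), a modest step, and no measurement shown explains why the two arms read alike.

The compounds shown leave open whether the free amino group of compound 3 matters in itself. A carboxylic acid or a longer chain on that phenyl ring would help to answer this, and none of these compounds carries either.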